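The source may hold more compounds than are shown below. What is called first, only, known or untested is meant among the compounds shown, and "the series" means these compounds.

Measured in a functional assay on B16 cells (Mus musculus) for inhibition, with a stated time of 72 h; on this read-out higher numbers stand for weaker inhibition and lower numbers for stronger inhibition:
- compound 1 `CCc1ccc(CN2CCCNC2=S)cc1`: 1300 nM
- compound 2 `S=C1NCCCN1CCCc1ccccc1`: 2100 nM
- compound 3 `O=C1NCCCN1Cc1ccccc1`: > 10000 nM (a limit of the assay, not a number)

Compound 1 and compound 2 lie within the usual scatter of each other. Compound 3 is the only one of the three without a number, and its entry of > 10000 nM is a limit.

Compound 4 `COc1ccc(CN2CCCNC2=O)cc1` is compound 3 with methoxy in place of hydrogen on an aromatic carbon, para to a group of 8 heavy atoms (methoxy in place of hydrogen on an aromatic carbon).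

Going by the values given here, no measured pair shows what this change does, so the expectation starts from compound 3 alone, whose > 10000 nM is a limit. No shift beyond the scatter is expected, and a second limit is the likeliest report. The expected change in this assay is a number no higher from compound 3 to compound 4 (the limit leaves the size open). For compound 4 the estimated value is 10000 nM, with an expected range of 4000 nM to 20000 nM.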

Compound 4, half-maximal inhibitory concentration: > 10000 nM
Compound 4 was reported as a limit; the forecaster's own chance of this, stated with the estimate: 65%; the middle value lies on the limit itself.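

No step can be read from compound 3 to compound 4, because both stand only as limits: the limit of > 10000 nM in this assay, at which 2 of the 4 values shown sit.

The compounds shown leave open what methoxy in place of hydrogen on an aromatic carbon does to a compound with a measurable value.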